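The source may report more compounds than this note shows. Statements on the series, on what has been measured and on what is new or still open speak of the compounds shown alone.

Measured compounds:
compound 1 `CN(C)CCn1cnnc1-c1cc(Oc2ccc(NC(=O)N/N=C/c3ccc(O)c(Br)c3)cc2F)ccn1` gives 5560 nM in an ADME assay on WI-38 cells (Homo sapiens) for cytotoxicity, read by MTT assay, with a stated time of 72 h; a higher number here means a weaker inhibitor, a lower number a stronger inhibitor;
compound 2 `CN(C)CCn1cnnc1-c1cc(Oc2ccc(NC(=O)N/N=C/c3cccc(Br)c3)cc2F)ccn1` gives 4230 nM in this assay.

Compound 2 holds the lowest of the two numbers; the only other, compound 1, lies a 1.3-fold lower number from compound 1 to compound 2 (0.12 log units; within the scatter) away, which is within the scatter. Compound 3 `CN(C)CCn1cnnc1-c1cc(Oc2ccc(NC(=O)N/N=C/c3ccc(Cl)cc3)cc2F)ccn1` has not yet been measured. It differs from compound 2 in one place: 4-chlorophenyl in place of 3-bromophenyl on a carbon with a double bond to nitrogen. Among the measured compounds shown here, no measured step touches that position; the sole step known, a 1.3-fold lower number from compound 1 to compound 2 (0.12 log units; within the scatter), concerns a hydroxy group elsewhere and was within the scatter. There is thus nothing in the measured pairs that would predict a change beyond the scatter for this exchange of one halogenated phenyl for another. Compound 3 is therefore expected to land close to compound 2, with an expected step of a 1.1-fold higher number from compound 2 to compound 3 (0.03 log units; within the scatter), and its estimated value is 4500 nM, in the range 2000 nM to 10000 nM.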

Compound 3, half-maximal inhibitory concentration: 1870 nM
Compound 3: middle estimate off by 2.4-fold (0.38 log units), on the high side; measured number outside the range, below it.
By their numbers in this assay, from the lowest: compound 3; then compounds 2 and 1 (each within the scatter of the next).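

In this assay, the aryl group on the carbon with a double bond to nitrogen can shift the number beyond the scatter, which the earlier hydroxy step did not show: 4-chlorophenyl in place of 3-bromophenyl gives a 2.3-fold lower number from compound 2 to compound 3 (0.35 log units; beyond the scatter) and the replacement of 3-bromo-4-hydroxyphenyl gives a 3.0-fold lower number from compound 1 to compound 3 (0.47 log units; beyond the scatter) at the same place. Compound 3 thus has the lowest number of the three, with both steps modest and both beyond the scatter. No available evidence accounts for this shift.

The exchange changes the halogen and its ring position together, so the compounds shown cannot tell which of the two matters; 4-bromophenyl and 3-chlorophenyl would separate them. From the compounds shown here alone, how an amine or a carboxylic acid on this phenyl ring would read remains open.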